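Removing the ring chlorine from a thiosemicarbazone series

A few compounds are considered here, and "the series" means these few. Any claim that something is new, unique, unknown or untested is made for them only; others in the source may bear on it.

Measured compounds:
compound 1 `CC1=CC[C@@H]([C@@](C)(O)CCCC(C)(C)NC(=S)N/N=C\c2ccccc2)CC1`, 36200 nM
compound 2 `CC1=CC[C@@H]([C@@](C)(O)CCCC(C)(C)NC(=S)N/N=C\c2ccc(C)cc2)CC1`, 45700 nM
compound 3 `CC1=CC[C@@H]([C@@](C)(O)CCCC(C)(C)NC(=S)N/N=C\c2ccccc2Cl)CC1`, > 100000 nM

In a functional assay on PCO3 cells (Homo sapiens) for cytotoxicity, read by sulforhodamine B assay (a higher number here means a weaker inhibitor of growth, a lower number a stronger inhibitor of growth), compound 1 gives 36200 nM and compound 2 gives 45700 nM, a difference a 1.3-fold higher number from compound 1 to compound 2 (0.10 log units; within the scatter). For compound 3 this assay reports only a limit, > 100000 nM, so compound 3 stands at the weak end of the three, and the steps of an at least 2.7-fold higher number from compound 1 to compound 3 (0.44 log units; beyond the scatter) and an at least 2.1-fold higher number from compound 2 to compound 3 (0.34 log units; beyond the scatter) are known only as lower bounds of their size, as noted in the limit of > 100000 nM in this assay, at which 1 of the 3 values shown sits.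

Compound 4 `CC1=CC[C@@H]([C@@](C)(O)CCCC(C)(C)NC(=S)N/N=C(/C)c2ccccc2)CC1` differs from compound 3 by a group of 9 heavy atoms (8 carbon, 1 nitrogen; one six-membered aromatic ring of carbon only) in place of a group of 9 heavy atoms (7 carbon, 1 nitrogen, 1 chlorine; one six-membered aromatic ring of carbon only), on an amide-type nitrogen. The chlorine leaves and a methyl enters on the carbon with a double bond to nitrogen. The bearing steps are those that introduced the chlorine, which moved the number upward by at least a modest amount; removing it is expected to reverse that, while the methyl, judging from the methyl step between compound 1 and compound 2, is expected to change little.

Compound 4 is therefore expected to give 40000 nM in this assay, with a range from 15000 nM to 120000 nM. The expected step from compound 3 is an at least 2.5-fold lower number from compound 3 to compound 4 (0.39 log units; beyond the scatter).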

Compound 4, concentration for total growth inhibition: > 100000 nM
Compound 4 gave a limit, no number (the forecaster's own chance of this, stated with the estimate: 30%); at least 2.5-fold (0.39 log units) between middle value and limit.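

Taking the chlorine off the ring did not bring the number back, since a methyl on the carbon with a double bond to nitrogen goes with an at least 2.7-fold higher number from compound 1 to compound 4 (0.44 log units; beyond the scatter) in this assay. A methyl at this carbon therefore does not behave like the methyl on an aromatic carbon, whose step stayed within the scatter, and exchanging that ring methyl for this one gives an at least 2.1-fold higher number from compound 2 to compound 4 (0.34 log units; beyond the scatter). The step linking compound 3 and compound 4 cannot be read, and the two steps above are lower bounds only: the limit of > 100000 nM in this assay, at which 2 of the 4 values shown sit.

The compounds shown leave open whether compound 3 and compound 4 differ at all in this assay. They also leave open whether an ethyl group on that carbon, or an amine on the aromatic ring, would give a number lower than that of compound 1.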